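Fluoro for Chloro on an Aromatic Ring

The source may report more compounds than this note shows. Statements on the series, on what has been measured and on what is new or still open speak of the compounds shown alone.

Compound 1 `Clc1ccc(-c2csc(N/N=C/c3cccs3)n2)cc1` — 96%
Compound 2 `Fc1ccc(-c2csc(N/N=C/c3ccc(Cl)cc3Cl)n2)cc1` — 93.3%

Among the compounds with values here, in a functional assay, read by spectrophotometry, with a stated time of 15 min, tested at 40 ug/mL (on this read-out higher numbers stand for a stronger effect at the one concentration tested and lower numbers for a weaker effect), compound 1 gives 96%, the higher of the two numbers measured so far. Compound 2 gives 93.3% in this assay, a number within the scatter of compound 1, so the two cannot be ranked against each other. Compound 3 `Fc1ccc(-c2csc(N/N=C/c3cccs3)n2)cc1` has not yet been measured in this assay. It differs from compound 1 in one place: fluoro in place of chloro on an aromatic carbon. Within the data shown here, no pair of measured compounds separates this single change, so the two measured values are the only guide. Because compound 1 reaches 96% and compound 2 reaches 93.3%, both already near the top of the scale, a change of one halogen on the same aromatic carbon is expected to leave the read-out much where it is. The step from compound 1 to compound 3 is estimated as a number 5 percentage points lower from compound 1 to compound 3 (within the scatter), a small drop that stays within the scatter. Compound 3 is therefore expected to give 91% in this assay, with a range from 78% to 98%.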

Compound 3, a percentage reported as inhibition, at one concentration (the size of the read-out at that concentration, not a potency): 93.3%
Compound 3: the middle estimate sits 2.3 percentage points below what was measured, and the stated range covers the measured number.
By their numbers in this assay, from the lowest: compounds 2, 3 and 1 (each within the scatter of the next).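

Within the data shown here, with compound 3, the change of fluoro in place of chloro on an aromatic carbon, para to a large group, can be read on its own for the first time: in this assay it amounts to a number 2.7 percentage points lower from compound 1 to compound 3 (within the scatter). Among these compounds, at this position, then, the two halogens cannot be told apart on this read-out, and compound 3, at 93.3%, keeps the high level seen for compound 1 at 96%, a result that the earlier compounds, which differ in more than one place, could only suggest. No measurement shown offers an explanation for this result, and nothing can be said about what either halogen contributes.

The compounds shown leave open how much of the effect depends on having a halogen at this position at all, as they include neither an amine, a carboxylic acid nor a methoxy group on that carbon, nor the ring carbon carrying only hydrogen. They also leave open whether compound 1 and compound 3 would separate in the strength of their effect at other concentrations, as a read-out at one concentration, close to the top of the scale, cannot show this.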